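Chloro for Methyl on a Shared Core: Two Placements

This account rests on a few compounds, and the source may have more. Where it says the series, first, only, none or still open, it means among the compounds named here.

Measured compounds:
compound 1, `Cc1cccc(-c2nc3cccnc3o2)c1`, 14%
compound 2, `Cc1ccccc1-c1nc2cccnc2o1`, 3%
compound 3, `Clc1cccc(-c2nc3cccnc3o2)c1`, 8%

Three compounds have been run in a functional assay on the whole organism for inhibition, with Rattus norvegicus as the target, at a dose of 30 mg/kg; on this read-out higher numbers stand for more inhibition at the one dose given (going by the name of the read-out) and lower numbers for less inhibition. Compound 1 gives 14% in this assay, compound 3 gives 8%, and compound 2 gives 3%. Compound 2 and compound 1 share the same atoms joined differently; the difference between the two cores is not broken down here. Compound 2 stands lowest of the three numbers, but only its gap to compound 1 lies beyond the scatter, while its gap to compound 3 lies within it.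

Going by the values given here, the one step that can be followed is the change from compound 1 to compound 3, (chloro in place of methyl on an aromatic carbon), which gave a number 6 percentage points lower from compound 1 to compound 3 (within the scatter).

The unmeasured compound 4, `Clc1ccccc1-c1nc2cccnc2o1`, is reached from compound 2 by the same kind of change, (chloro in place of methyl on an aromatic carbon). The two placements are not the same: in the first the chloro sits meta to a group of 9 heavy atoms, in the second ortho to a group of 9 heavy atoms. Among the compounds with values here, the step from compound 1 to compound 3 is the only guide, and it was small. Compound 4 is therefore expected to stay close to compound 2, with an estimated step of a number 1 percentage points lower from compound 2 to compound 4 (within the scatter), because compound 2 already gives 3% and little room for a drop remains. For compound 4 the expected value in this assay is 2%, estimated between -6% and 12%.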

Compound 4, a percentage reported as inhibition, in the whole organism at one dose (the size of the read-out at that dose, not a potency): 50%
Compound 4: middle estimate off by 48 percentage points, on the low side; measured number outside the range, above it.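

In this assay chloro in place of methyl on an aromatic carbon gave a number 47 percentage points higher from compound 2 to compound 4 (beyond the scatter) and so produced a large step on the core of compound 2. Set beside the earlier step, the same change did not carry over in size or direction from one core to the other: the same change on two cores in this assay, a number 6 percentage points lower (within the scatter) from compound 1 to compound 3 and a number 47 percentage points higher (beyond the scatter) from compound 2 to compound 4, 53 percentage points apart, beyond the scatter of two such steps. Going by these compounds alone, this shows that, in this series, the step seen on one core is a poor guide to the step on the other, but it rests on only two pairs and does not show why they differ, nor whether the chloro placed ortho to a group of 9 heavy atoms accounts for the gap or what rule would hold on any further core.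

The compounds shown leave open whether the large step belongs to chloro alone or would also appear with fluoro, bromo, methoxy or an amine on that same aromatic carbon. They also leave open how compound 4 behaves at any other dose, since the read-out gives the size of the inhibition at one dose and not a potency.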